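A methyl moved from the 4- to the 3-position

This account rests on a few compounds, and the source may have more. Where it says the series, first, only, none or still open, it means among the compounds named here.

compound 1 `COC(=O)[C@H](CCSC)NC(=O)c1ccc(NCc2cncn2Cc2ccc(C)cc2)cc1-c1ccccc1` — > 10 uM
compound 2 `CSCC[C@H](NC(=O)c1ccc(NCc2cncn2Cc2ccc(C)cc2)cc1-c1ccccc1)C(=O)O` — > 10 uM
compound 3 `CSCC[C@H](NC(=O)c1ccc(CNCc2[nH]cnc2C)cc1-c1ccccc1C)C(=O)O` — > 10 uM

In a functional assay on NIH3T3 cells (Mus musculus) (on this read-out lower numbers stand for an effect already at smaller amounts and higher numbers for an effect only at larger amounts of compound), compound 1 gives > 10 uM, which is a limit of the assay and not a number. Compound 2 likewise gives > 10 uM, also a limit. Compound 3 gives > 10 uM, again a limit. All three values thus rest on (the limit of > 10 uM in this assay, at which 3 of the 3 values shown sit). Going by the values given here, the single step between two measured compounds that differ in one place, a step that the two limits leave unreadable from compound 1 to compound 2, is unreadable, and its size stays unknown.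

Compound 4 `COC(=O)[C@H](CCSC)NC(=O)c1ccc(NCc2cncn2Cc2cccc(C)c2)cc1-c1ccccc1` differs from compound 1 by 3-methylphenyl in place of 4-methylphenyl on a saturated chain carbon bound to an aromatic nitrogen. Among the compounds with values here, no measured step touches this place in the shared core of compound 1; the one measured step concerns a different place and cannot be read anyway. The measured compounds therefore give no direction for the change, and no step beyond the usual scatter is expected in this assay.

Because compound 1 gives > 10 uM, compound 4 is expected most likely to sit at the same limit. For compound 4 the estimate is 20 uM, with a range from 5 uM to 80 uM. The step from compound 1 to compound 4 that this estimate means, a step that the limit leaves unreadable from compound 1 to compound 4, is expected to be none beyond the scatter.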

Compound 4, concentration for half-maximal effect: > 10 uM
Compound 4 ended at the assay's limit; the forecaster's own chance of this, stated with the estimate: 85%; the middle value does not contradict the limit.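

In this assay compound 4 gives > 10 uM, which is a limit of the assay and not a number. The step from compound 1 to compound 4 therefore cannot be read, and no other step can be read either: the limit of > 10 uM in this assay, at which 4 of the 4 values shown sit. The compounds shown leave open whether 3-methylphenyl in place of 4-methylphenyl changes the effect at all.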